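Amine ends of the side chain: compound 3 ahead

The source may report more compounds than this note shows. Statements on the series, on what has been measured and on what is new or still open speak of the compounds shown alone.

Measured in a functional assay on DU-145 cells (Homo sapiens) for antiproliferative activity, read by MTT assay, with a stated time of 72 h; a higher number here means a weaker inhibitor, a lower number a stronger inhibitor:
compound 1 `CCOC(=O)C1CCN(CCCOc2cc3ncnc(Nc4ccc(C#N)cc4)c3cc2OC)CC1`: 52300 nM
compound 2 `COc1cc2c(Nc3ccc(C#N)cc3)ncnc2cc1OCCCN1CCc2ccccc2C1`: > 100000 nM (a limit, not a number)

Compound 2 stands at a limit of the assay: the limit of > 100000 nM in this assay, at which 1 of the 2 values shown sits. Compound 3 `COc1cc2c(Nc3ccc(C#N)cc3)ncnc2cc1OCCCN1CCC(N(C)C)CC1` differs from compound 2 in this way: 4-(dimethylamino)piperidin-1-yl in place of 1,2,3,4-tetrahydroisoquinolin-2-yl on a saturated chain carbon, three bonds along the chain from an oxygen on an aromatic ring. Within the data shown here, the one measured step at this place is an at least 1.9-fold higher number from compound 1 to compound 2 (0.28 log units; that floor lies within the scatter). It gives only a floor and fixes no size. Compound 3 carries a piperidin-1-yl ring, as does compound 1 at 52300 nM, so a value near that one is expected. The expected step in this assay, toward a lower number, is an at least 2.0-fold lower number from compound 2 to compound 3 (0.30 log units; that floor lies within the scatter). For compound 3 the estimated value is 50000 nM, with an expected range of 18000 nM to 100000 nM.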

Compound 3, half-maximal inhibitory concentration: 28300 nM
The estimate for compound 3 lay 1.8-fold (0.25 log units) above the measured number, and the stated range covers the measured number.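

In this assay, among these compounds, the entry of 4-(dimethylamino)piperidin-1-yl gives an at least 3.5-fold lower number from compound 2 to compound 3 (0.54 log units; beyond the scatter) as the first step at this place beyond the scatter. That step stays a floor because compound 2 has a limit, not a number: the limit of > 100000 nM in this assay, at which 1 of the 3 values shown sits. With dimethylamino in place of ethoxycarbonyl on a saturated ring carbon, a 1.8-fold lower number from compound 1 to compound 3 (0.27 log units; within the scatter) stays within the scatter, so these two ring substituents cannot be told apart here.

Open, from the compounds shown here alone, is whether a carboxylic acid on that ring carbon, or a morpholine at the chain end, would change the picture. Going by these compounds, the effect of a longer chain also remains open.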